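The compounds below may be only part of what the source reports. "The series", "measured", "known", "first", "only" and "open" are said of these compounds alone.

Measured compounds:
- Compound 1, `COc1cc(C)cc(-c2c(-c3ccnc(-c4ccc(N(C)C)cc4)c3)cnn2CC#N)c1`, in a functional assay on SK-MEL-2 cells (Homo sapiens) for inhibition, read by sulforhodamine B assay, with a stated time of 48 h (a lower number here means a stronger inhibitor of growth, a higher number a weaker inhibitor of growth), gives 204 nM.
- Compound 2, `COc1cc(C)cc(-c2nn(CC#N)cc2-c2ccnc(-c3ccc(N(C)C)cc3)c2)c1`, in this assay gives 1010 nM.
- Compound 3, `COc1cc(C)cc(-c2nn(CC#N)cc2-c2ccc(-c3cccc(C(C)=O)c3)nc2)c1`, in this assay gives 3730 nM.

Among these three numbers, compound 2 holds the second highest. Compound 1 gives a lower number than compound 2, and compound 3 a higher one; both of these gaps are beyond the usual scatter of the measurement, so compound 2 sits clearly between the other two in this assay.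

The new compound, compound 4, `Cc1cc(O)cc(-c2nn(CC#N)cc2-c2ccnc(-c3ccc(N(C)C)cc3)c2)c1`, is compound 2 with one small change: hydrogen in place of methyl on an oxygen on an aromatic ring. For the measured compounds named here, no measured pair shows this exact change, so there is no directly comparable step to lean on. A change of this size at an oxygen on the aromatic ring is expected to move the number only a little, most likely staying within the scatter, with a modest lean toward a higher number. The step from compound 2 to compound 4 is therefore estimated as a 1.5-fold higher number from compound 2 to compound 4 (0.17 log units; within the scatter), and compound 4 is expected to give about 1500 nM in this assay, somewhere between 500 nM and 4500 nM.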

Compound 4, concentration for 50% growth inhibition: 4150 nM
Estimate against measurement, compound 4: 2.8-fold (0.44 log units) below, within the range that was stated.
By their numbers in this assay, from the lowest: compound 1; then compound 2; then compounds 3 and 4 (each within the scatter of the next).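

Going from methoxy to hydroxy on the 3-methoxy-5-methylphenyl group in this assay gives a 4.1-fold higher number from compound 2 to compound 4 (0.61 log units; beyond the scatter) and so weakens growth inhibition. This is the first pair shown that differs in one place, so the earlier compounds could say nothing about this position, and it shows that the methyl on this oxygen is not a silent detail: losing that single carbon changes the result by more than the scatter. Nothing available explains the size of this step.

Still open, as far as these compounds go, is whether the methyl or the oxygen matters more, a question that an ethoxy group, an amine or a fluorine at this place could help to answer. From the compounds shown here alone, it is also open whether the same change would act alike on the core of compound 1.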